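The source may report more compounds than this note shows. Statements on the series, on what has been measured and on what is new or still open speak of the compounds shown alone.

Measured compounds:
Compound 1, `CS(=O)(=O)c1ccc(Cc2n[nH]c(=S)n2/N=C/c2c(F)cccc2Cl)cc1`, in a functional assay on HeLa cells (Homo sapiens) for cytotoxicity, read by MTT assay, with a stated time of 48 h (a lower number here means that less compound is needed, a higher number that more compound is needed for the effect), gives 25000 nM.
Compound 2, `CS(=O)(=O)c1ccc(Cc2n[nH]c(=S)n2/N=C/c2ccc(-c3ccccc3)cc2)cc1`, in this assay gives 50000 nM.

Compound 2 has the higher of the two numbers, but its gap to compound 1 lies within the scatter, so the two cannot be told apart. Compound 3, `CSc1ccc(/C=N/n2c(Cc3ccc(S(C)(=O)=O)cc3)n[nH]c2=S)cc1`, has not yet been measured. It differs from compound 2 in one place: methylsulfanyl in place of phenyl on an aromatic carbon. Going by the values given here, no measured pair shows this change, so nothing here points to a direction; the step in this assay is expected to stay within the scatter. For compound 3 the expected value is 40000 nM, between 15000 nM and 100000 nM, which means an estimated step of a 1.3-fold lower number from compound 2 to compound 3 (0.10 log units; within the scatter).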

Compound 3, half-maximal effective concentration: 50000 nM
Beside the measured number, compound 3's estimate is 1.3-fold (0.10 log units) below it, within the range that was stated.
By their numbers in this assay, from the lowest: compounds 1, 2 and 3 (each within the scatter of the next).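

In this assay putting methylsulfanyl in place of phenyl, para to a large group, gives no change at the digits printed from compound 2 to compound 3 (within the scatter) and so shows that this position can lose a whole aromatic ring with no readable shift. Changing 2-chloro-6-fluorophenyl to 4-(methylsulfanyl)phenyl gives a 2.0-fold higher number from compound 1 to compound 3 (0.30 log units; within the scatter) and so also cannot be told from the scatter. Nothing available explains why these numbers stay so close. On these data alone, whether an amine or a carboxylic acid at this position would move the number beyond the scatter remains open. So does whether any change here matters in this assay at all.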